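A few compounds are considered here, and "the series" means these few. Any claim that something is new, unique, unknown or untested is made for them only; others in the source may bear on it.

Measured so far:
Compound 1, `COc1ccc(-c2nc(N)c3nc(-c4ccccc4)sc3n2)cc1`: in a functional assay on CHO cells for antagonist activity at adenosine receptor A2b (Homo sapiens), read by cAMP accumulation, with a stated time of 10 min (a higher number here means a weaker inhibitor, a lower number a stronger inhibitor), compound 1 gives > 30000 nM, a limit of the assay and not a number.
Compound 2, `COc1cccc(-c2nc(N)c3nc(-c4ccccc4)sc3n2)c1`: in this assay compound 2 gives > 30000 nM, again a limit.
Compound 3, `Nc1nc(-c2cccc(O)c2)nc2sc(-c3ccccc3)nc12`: in this assay compound 3 gives > 30000 nM, also a limit.

Compound 3 therefore stands at the same limit as the two other compounds; nothing in these numbers sets it apart from them, because of the limit of > 30000 nM in this assay, at which 3 of the 3 values shown sit. As far as these compounds go, the steps between the measured compounds cannot be read: the step that the two limits leave unreadable from compound 1 to compound 2, the step that the two limits leave unreadable from compound 1 to compound 3 and the step that the two limits leave unreadable from compound 2 to compound 3 are all hidden by the two limits, so the effect of moving or removing a group on the phenyl ring is unknown.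

Compound 4, `Cc1ccc(-c2nc(N)c3nc(-c4ccccc4)sc3n2)o1`, is the one not yet measured. It differs from compound 3 in one place: 5-methylfuran-2-yl in place of 3-hydroxyphenyl on an aromatic carbon. Among the compounds with values here, none of the measured steps concerns a change of this kind, and none of them gives a readable size in this assay, so no direction can be drawn from them; the only support is that every measured compound sits at the limit. The step from compound 3 to compound 4 is estimated as a number no higher from compound 3 to compound 4 (the limit leaves the size open), meaning a compound that is expected to remain weak. For compound 4 the estimated value in this assay is 30000 nM, expected to lie between 3000 nM and 300000 nM.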

Compound 4, half-maximal inhibitory concentration: > 30000 nM
Compound 4: no number, only a limit; the forecaster's own chance of this, stated with the estimate: 70%; the middle value sits exactly at the limit.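

Compound 4 also gives only a limit of the assay, so the steps to it from compound 1, compound 2 and compound 3 cannot be read, because all the values share one limit: the limit of > 30000 nM in this assay, at which 4 of the 4 values shown sit. In this assay the compounds shown leave open which group on this aromatic carbon of the shared core, if any, would give a measurable inhibitor.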